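This account rests on a few compounds, and the source may have more. Where it says the series, first, only, none or still open, it means among the compounds named here.

The measured compounds:

Compound 1 `CS(=O)(=O)c1ccc(-n2c(=O)n(Cc3cc4cc(Cl)ccc4n3CCCC#N)c3cnccc32)cc1`: > 50000 nM
Compound 2 `O=c1n(Cc2cc3ccncc3n2CCCCO)c2cnccc2n1C1CC1`: > 100000 nM
Compound 3 `CC(C)CCn1c(Cn2c(=O)n(C3CC3)c3ccncc32)nc2nc(Cl)ccc21`: > 50000 nM

All three readings come from an ADME assay on HeLa cells (Homo sapiens) for cytotoxicity, read by ATP content, with a stated time of 3 days; on this read-out higher numbers stand for lower toxicity in this test and lower numbers for higher toxicity in this test. None of them is a number. For compound 1 the reading > 50000 nM is a limit of this assay, and compound 1 therefore sits at the limit of > 50000 nM in this assay, at which 2 of the 3 values shown sit. Compound 3 also sits at that limit. Compound 2 sits at the limit of > 100000 nM in this assay, at which 1 of the 3 values shown sits, which is likewise a limit and not a number. Nothing among these three compounds separates them; each is simply too little toxic for this assay to resolve.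

Compound 4 `N#CCCCn1c(Cn2c(=O)n(-c3ccc(C(=O)NC4CC4)cc3)c3ccncc32)cc2cc(Cl)ccc21` differs from compound 1 in one place: cyclopropylcarbamoyl in place of methylsulfonyl on an aromatic carbon. Among the compounds with values here, no measured pair with such a change is available, so the expectation rests on compound 1 alone. Since every reading so far is a limit, the step from compound 1 to compound 4 is expected to be a step that the limit leaves unreadable from compound 1 to compound 4 in this assay, nothing beyond the scatter, and most likely another limit. Compound 4 is estimated at 60000 nM, within 20000 nM to 200000 nM.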

Compound 4, half-maximal cytotoxic concentration: > 50000 nM
Compound 4: a limit, no number (the forecaster's own chance of this, stated with the estimate: 75%); the middle value is on the limit's open side.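

Within the data shown here, compound 1 and compound 4 both stand only as limits in this assay, so no step between them can be read. The compounds shown leave open whether any of them has a half-maximal cytotoxic concentration that this assay can resolve as a number.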